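Swapping fluoro for isopropoxy on a phenyl ring

The source may report more compounds than this note shows. Statements on the series, on what has been measured and on what is new or still open speak of the compounds shown alone.

Compound 1 `CC(C)n1c(-c2ccccc2)cc2onc(-c3ccccc3)c2c1=O`: > 10000 nM
Compound 2 `Cn1c(-c2ccccc2)cc2onc(-c3cccnc3)c2c1=O`: 240 nM
Compound 3 `Cn1c(-c2ccc(F)cc2)cc2onc(-c3ccccc3)c2c1=O`: 72 nM

All three share one core and were tested in a functional assay on CHO cells for antagonist activity at metabotropic glutamate receptor 7 (Rattus norvegicus), read by FLIPR and calcium flux; a lower number here means a stronger inhibitor, a higher number a weaker inhibitor. Compound 1 gives only a limit, > 10000 nM, so its potency is not known as a number. Of the two real numbers, compound 3 gives the lowest, 72 nM, and compound 2 gives the nearest, 240 nM, a gap that lies beyond the usual scatter of this assay. Compound 3 is therefore the stronger inhibitor of the two.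

The next compound, compound 4 `CC(C)Oc1ccc(-c2cc3onc(-c4ccccc4)c3c(=O)n2C)cc1`, keeps everything of compound 3 except one group on the phenyl ring attached to the nitrogen-bearing ring of the core: isopropoxy in place of fluoro on an aromatic carbon. Going by the values given here, no pair of measured compounds shows what such an exchange does in this assay, so there is no measured step to lean on. The change is small in kind but adds bulk and one hydrogen-bond acceptor, and the expectation is a step of modest size, most likely within the scatter or a little weaker. For compound 4 the estimate in this assay is 110 nM, with a plausible range from 30 nM to 400 nM, which means an expected step of a 1.5-fold higher number from compound 3 to compound 4 (0.18 log units; within the scatter).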

Compound 4, half-maximal inhibitory concentration: > 10000 nM
Compound 4 was reported as a limit; the forecaster's own chance of this, stated with the estimate: 5%; middle value at least 90-fold (1.95 log units) away from the limit.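

This position, on an aromatic carbon para to a large group, does not accept every group: in this assay, isopropoxy in place of fluoro gives an at least 130-fold higher number from compound 3 to compound 4 (2.14 log units; beyond the scatter). The value of compound 4, > 10000 nM, is a limit and not a number, so this step gives only the smallest size the change could have. This is the only exchange in one place among the compounds shown, and it takes a compound with a measured value to the limit of the read-out: the limit of > 10000 nM in this assay, at which 2 of the 4 values shown sit.

The compounds shown do not tell whether the loss comes with the oxygen attached to the ring or with the branched carbons of the isopropoxy group, and methoxy, a close relative with a smaller chain, would help to separate the two. Nor do they show how chloro, an amine or a plain hydrogen would behave at this same carbon. Going by these compounds, what the position accepts beyond fluoro therefore remains unknown.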